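A few compounds are considered here, and "the series" means these few. Any claim that something is new, unique, unknown or untested is made for them only; others in the source may bear on it.

Measured compounds:
compound 1 `CCOC(=O)C1=C(C)NC(C)=C(C(=O)OCC)C1c1ccc(OCC(=O)Nc2ccc(C)cc2)cc1`; in a functional assay on the whole organism (strain Wistar) for inhibition, with Rattus norvegicus as the target, read by paw edema, with stated times of 30 min and 2 h, at a dose of 20 mg/kg (on this read-out lower numbers stand for less inhibition and higher numbers for more inhibition at the one dose given (going by the name of the read-out)), compound 1 gives 62.2%.
compound 2 `CCOC(=O)C1=C(C)NC(C)=C(C(=O)OCC)C1c1ccc(OCC(=O)NNC(=O)c2ccccc2)cc1`; compound 2 gives 44.5%.

Among the compounds with values here, compound 1 stands highest of the two numbers; its nearest neighbour is compound 2, and the single measured step, a number 17.7 percentage points lower from compound 1 to compound 2 (beyond the scatter), lies beyond the scatter. That step exchanges one group on an amide-type nitrogen for another, as does the change to the unmeasured compound 3 `CCOC(=O)C1=C(C)NC(C)=C(C(=O)OCC)C1c1ccc(OCC(=O)NN2C(=O)c3ccccc3C2=O)cc1`: a group of 11 heavy atoms (8 carbon, 1 nitrogen, 2 oxygen; one five-membered non-aromatic ring with 1 hetero atom, one six-membered aromatic ring of carbon only) in place of a group of 7 heavy atoms (7 carbon; one six-membered aromatic ring of carbon only), on an amide-type nitrogen. Within the data shown here, the entering group, with its nitrogen and two oxygen atoms, is closer in kind to the benzamido group of compound 2 than to the 4-methylphenyl group of compound 1, so the one measured step serves as the guide. A drop of similar size is therefore expected, a number 15.2 percentage points lower from compound 1 to compound 3 (beyond the scatter). Compound 3 is thus estimated at 47%, within a range from 33% to 61%.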

Compound 3, a percentage reported as inhibition, in the whole organism at one dose (the size of the read-out at that dose, not a potency): 57.2%
Estimate against measurement, compound 3: 10.2 percentage points below; the measured number falls inside the stated range.
By their numbers in this assay, from the lowest: compound 2; then compounds 3 and 1 (each within the scatter of the next).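

In this assay, placing the group with the five-membered ring on the amide-type nitrogen instead of 4-methylphenyl gives a number 5 percentage points lower from compound 1 to compound 3 (within the scatter), so these two quite different groups cannot be told apart here. Set against the benzamido group, the same ring-bearing group gives a number 12.7 percentage points higher from compound 2 to compound 3 (beyond the scatter), which shows that a group carrying nitrogen and oxygen at this place need not bring the lower number seen with compound 2, now the only one of the three that stands apart. No measured evidence explains why the benzamido group differs from the other two.

As far as these compounds go, it remains open how a plain phenyl ring, an ethyl chain or a carboxylic acid would behave at this place. Because each compound is read at a single dose, these numbers also leave their potency open.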